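The source may hold more compounds than are shown below. What is called first, only, known or untested is meant among the compounds shown, and "the series" means these compounds.

Measured so far:
compound 1, `O=C1O[C@H]([C@@H](O)Cn2cc(-c3cc(C(F)(F)F)cc(C(F)(F)F)c3)nn2)C(OCc2ccccc2)=C1OCc1ccccc1`: 35500 nM
compound 2, `CCCCCc1ccc(-c2cn(C[C@H](O)[C@H]3OC(=O)C(OCc4ccccc4)=C3OCc3ccccc3)nn2)cc1`: 8390 nM
compound 3, `COc1ccccc1-c1cn(C/C=C2\OC(=O)C(OCc3ccccc3)=C2OCc2ccccc2)nn1`: a limit, > 100000 nM

All three were tested in a functional assay on HeLa cells (Homo sapiens) for antiproliferative activity, read by MTT assay, with a stated time of 72 h; on this read-out lower numbers stand for stronger inhibition and higher numbers for weaker inhibition. Of the two compounds with a number, compound 2 gives 8390 nM, the lower one, and the number of compound 1, 35500 nM, lies higher by more than the usual scatter. For compound 3 the assay gives only a limit, > 100000 nM, and no number.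

Compound 4, `Cc1ccc(-c2cn(C[C@H](O)[C@H]3OC(=O)C(OCc4ccccc4)=C3OCc3ccccc3)nn2)cc1`, differs from compound 2 in one place: hydrogen in place of butyl on a saturated chain carbon bound to an aromatic carbon. Within the data shown here, with the pentyl shortened to methyl, a step toward weaker inhibition is expected, probably beyond the scatter, since the pentylphenyl compound 2 is the one with the lower number. The step from compound 2 to compound 4 is expected to be a 3.0-fold higher number from compound 2 to compound 4 (0.47 log units; beyond the scatter). Compound 4 is thus estimated at 25000 nM, between 9000 nM and 70000 nM.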

Compound 4, half-maximal inhibitory concentration: 25500 nM
For compound 4 the middle estimate is 1.0-fold (0.01 log units) below the measured one; the measured number falls inside the stated range.
By their numbers in this assay, from the lowest: compound 2; then compounds 4 and 1 (each within the scatter of the next). At a limit, above all of these: compound 3.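

Compounds 2 and 4 are the only pair shown that differs in one place, so the chain can be judged on its own. The step is a 3.0-fold higher number from compound 2 to compound 4 (0.48 log units; beyond the scatter) in this assay when pentyl becomes methyl, so in this pair the longer chain goes with stronger inhibition. No measurement shown explains this step.

On these data alone, it remains open whether butyl or a longer chain such as octyl would continue this trend. As far as these compounds go, it is also open how an amine or a carboxylic acid at the end of the chain would read.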